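This account rests on a few compounds, and the source may have more. Where it says the series, first, only, none or still open, it means among the compounds named here.

Measured so far in a functional assay on A549 cells (Homo sapiens) for inhibition, read by MTT assay, with a stated time of 24 h; on this read-out lower numbers stand for stronger inhibition and higher numbers for weaker inhibition:
- compound 1 `CC1(C)[C@H]2CC[C@]1(C)N(Cc1cn(-c3cccc(C#N)c3)nn1)C(=O)C2`: 440 nM
- compound 2 `CC1(C)[C@H]2CC[C@]1(C)N(Cc1cn(-c3ccc(F)cc3)nn1)C(=O)C2`: 230 nM
- compound 3 `CC1(C)[C@H]2CC[C@]1(C)N(Cc1cn(-c3ccccc3Cl)nn1)C(=O)C2`: 70 nM

Not yet measured:
- compound 4 `CC1(C)[C@H]2CC[C@]1(C)N(Cc1cn(-c3ccc(Br)cc3)nn1)C(=O)C2`

Compound 2 stands close to one neighbour, with a 1.9-fold lower number from compound 1 to compound 2 (0.28 log units; within the scatter), and apart from the other, with a 3.3-fold lower number from compound 2 to compound 3 (0.52 log units; beyond the scatter). The change under consideration is bromo in place of fluoro on an aromatic carbon, para to a large group.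

Within the data shown here, no measured pair exchanges one halogen for another at this place, so the evidence is indirect. Among the measured compounds shown here, the steps that bear on it all alter the same aryl group. The largest is a 6.3-fold lower number from compound 1 to compound 3 (0.80 log units; beyond the scatter), and the step of a 3.3-fold lower number from compound 2 to compound 3 (0.52 log units; beyond the scatter) is also modest, but both introduce 2-chlorophenyl, a different substitution place. The step of a 1.9-fold lower number from compound 1 to compound 2 (0.28 log units; within the scatter) shows that a larger change of substituent can leave the number within the scatter.

In this assay, no step beyond the scatter is therefore expected, with only a slight lean towards a lower number. The estimated step is a 1.2-fold lower number from compound 2 to compound 4 (0.08 log units; within the scatter). For compound 4 the expected value is 190 nM, with an estimated range of 80 nM to 450 nM.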

Compound 4, half-maximal inhibitory concentration: 80 nM
Compound 4: middle estimate off by 2.4-fold (0.38 log units), on the high side; the range from low to high includes it.
By their numbers in this assay, from the lowest: compounds 3 and 4 (each within the scatter of the next); then compounds 2 and 1 (each within the scatter of the next).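

In this assay, among these compounds, the exchange of one halogen for another on an aromatic carbon, para to a large group, proves not to be a neutral change: a 2.9-fold lower number from compound 2 to compound 4 (0.46 log units; beyond the scatter) is a step beyond the scatter, and it is the first that keeps the substitution place of the aryl group fixed. A low number is also not confined to 2-chlorophenyl, since a 1.1-fold higher number from compound 3 to compound 4 (0.06 log units; within the scatter) stays within the scatter and a 5.5-fold lower number from compound 1 to compound 4 (0.74 log units; beyond the scatter) lies beyond it. The data shown offer no measured explanation for the gap between fluoro and bromo.

On these data alone, with only fluoro and bromo at this place, how chloro, iodo or methyl would read remains open. As far as these compounds go, an amine or a carboxylic acid at the same place is equally open, so the tolerance of this position for such groups cannot be judged.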